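This account rests on a few compounds, and the source may have more. Where it says the series, first, only, none or still open, it means among the compounds named here.

Measured so far in a functional assay on A549 cells (Homo sapiens) for inhibition, read by sulforhodamine B assay, with a stated time of 72 h; on this read-out higher numbers stand for weaker inhibition of growth and lower numbers for stronger inhibition of growth:
compound 1 `CNC(=O)/C=C/c1ccncc1-c1ccc2ccccc2c1` gives 6620 nM
compound 2 `CCOC(=O)/C=C/c1ccncc1-c1ccc2ccccc2c1` gives 5380 nM
compound 3 `CN(C)C(=O)/C=C/c1ccncc1-c1ccc2ccccc2c1` gives 5800 nM

Compound 3, at 5800 nM, cannot be told apart from the other two (a 1.1-fold lower number from compound 1 to compound 3 (0.06 log units; within the scatter)) (a 1.1-fold higher number from compound 2 to compound 3 (0.03 log units; within the scatter)). The move to compound 4 `O=C(/C=C/c1ccncc1-c1ccc2ccccc2c1)NC1CC1` puts cyclopropylamino in place of dimethylamino on a carbonyl carbon. The amide hydrogen returns, as in compound 1. The closest measured change is methyl in place of hydrogen on an amide-type nitrogen (a 1.1-fold lower number from compound 1 to compound 3 (0.06 log units; within the scatter)), and it stays within the scatter. Replacing methylamino with ethoxy on the carbonyl carbon also stays within it (a 1.2-fold lower number from compound 1 to compound 2 (0.09 log units; within the scatter)). Among the measured compounds shown here, no measured compound carries a ring on that nitrogen, so this part of the change has no direct support. On these small steps, no shift beyond the scatter is expected in this assay (a 1.0-fold lower number from compound 3 to compound 4 (0.02 log units; within the scatter)). The expected value for compound 4 is 5600 nM, with an estimated range of 2800 nM to 11000 nM.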

Compound 4, concentration for 50% growth inhibition: 5840 nM
Compound 4: middle estimate off by 1.0-fold (0.02 log units), on the low side; low and high end bracket the measured number.
By their numbers in this assay, from the lowest: compounds 2, 3, 4 and 1 (each within the scatter of the next).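

In this assay a ring on the amide nitrogen now has a reading: cyclopropylamino in place of dimethylamino on the carbonyl carbon gives no step beyond the scatter (a 1.0-fold higher number from compound 3 to compound 4 (0.00 log units; within the scatter)). Cyclopropyl in place of methyl on the amide-type nitrogen (a 1.1-fold lower number from compound 1 to compound 4 (0.05 log units; within the scatter)) and cyclopropylamino in place of ethoxy (a 1.1-fold higher number from compound 2 to compound 4 (0.04 log units; within the scatter)) also stay within it, so all four groups on this carbonyl carbon read alike, the three-membered ring included. Nothing available explains this result.

From the compounds shown here alone, whether a carboxylic acid, a longer chain ending in an amine or a morpholine ring on the carbonyl carbon would give a step beyond the scatter remains open. Going by these compounds, all four compounds share the core and the double-bonded chain, so how far the number depends on those parts also remains open.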